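The source may hold more compounds than are shown below. What is called first, only, known or untested is meant among the compounds shown, and "the series" means these compounds.

Measured compounds:
Compound 1 `CC1=C(C(=O)OCC2CCN(C(=O)OC(C)(C)C)CC2)C(c2cccc(Br)c2)C2=C(CC(C)(C)CC2=O)N1` gives 360 nM in an assay on HEK293 cells for inhibition of neurogenic locus notch homolog protein 1 (Homo sapiens), read by a luciferase reporter and resazurin assay, with a stated time of 16 h; a higher number here means a weaker inhibitor, a lower number a stronger inhibitor.
Compound 2 `CC1=C(C(=O)OCC2CCN(C(=O)OC(C)(C)C)CC2)C(c2ccc3c(c2)OCCO3)C2=C(CC(C)(C)CC2=O)N1` gives 1520 nM in this assay.
Compound 3 `CC1=C(C(=O)OCC2CCN(C(=O)OC(C)(C)C)CC2)C(c2cccc(C(F)(F)F)c2)C2=C(CC(C)(C)CC2=O)N1` gives 760 nM in this assay.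

Compound 3 stands second highest of the three numbers in this assay: the nearer step is a 2.0-fold lower number from compound 2 to compound 3 (0.30 log units; within the scatter), and the further step is a 2.1-fold higher number from compound 1 to compound 3 (0.32 log units; beyond the scatter). Compound 4 `CC1=C(C(=O)OCC2CCN(C(=O)OC(C)(C)C)CC2)C(c2ccc(-c3ccccc3)cc2)C2=C(CC(C)(C)CC2=O)N1` differs from compound 3 by 4-phenylphenyl in place of 3-(trifluoromethyl)phenyl on a saturated ring carbon. Two measured steps exchange the aryl group on that same saturated ring carbon: a 4.2-fold higher number from compound 1 to compound 2 (0.63 log units; beyond the scatter) and a 2.0-fold lower number from compound 2 to compound 3 (0.30 log units; within the scatter). Neither involves 4-phenylphenyl, so the direction is uncertain; the aryl exchanges seen so far have moved the number by modest amounts in either direction. Compound 4 is therefore expected to give 1500 nM, ranging from 400 nM to 6000 nM, an estimated step of a 2.0-fold higher number from compound 3 to compound 4 (0.30 log units; within the scatter).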

Compound 4, half-maximal inhibitory concentration: > 10000 nM
Compound 4: only a limit was reported (the forecaster's own chance of this, stated with the estimate: 5%); at least 6.6-fold (0.82 log units) between middle value and limit.
By their numbers in this assay, from the lowest: compound 1; then compounds 3 and 2 (each within the scatter of the next). At a limit, above all of these: compound 4.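

For compound 4, this assay gives only a limit: the limit of > 10000 nM in this assay, at which 1 of the 4 values shown sits. On this saturated ring carbon, the earlier aryl exchanges moved the number modestly at most, whereas 4-phenylphenyl gives an at least 13-fold higher number from compound 3 to compound 4 (1.11 log units; beyond the scatter), along with an at least 6.5-fold higher number from compound 2 to compound 4 (0.81 log units; beyond the scatter) and an at least 27-fold higher number from compound 1 to compound 4 (1.44 log units; beyond the scatter). This position therefore does not accept every aryl group as readily as compounds 1, 2 and 3 suggested. The compounds shown leave open whether a pyridine ring, a cyclohexyl group or an aryl ring carrying an amine on this carbon would behave like 4-phenylphenyl or like the earlier aryl groups.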